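Moving from 4-Methylphenyl to 2-Chlorophenyl on the Amide

The source may report more compounds than this note shows. Statements on the series, on what has been measured and on what is new or still open speak of the compounds shown alone.

Compound 1 `CCNC(=O)c1cc(-c2ccc(F)cc2F)ccc1OC(C)=O`: 23.9%
Compound 2 `CC(=O)Oc1ccc(-c2ccc(F)cc2F)cc1C(=O)NCc1ccccc1`: 16.6%
Compound 3 `CC(=O)Oc1ccc(-c2ccc(F)cc2F)cc1C(=O)Nc1ccc(C)cc1`: 31%

All three compounds were tested in a functional assay on the whole organism (strain Kunming) for inhibition, with Mus musculus as the target, in the writhing test, at a dose of 40 mg/kg by the oral route (a lower number here means less inhibition, a higher number more inhibition at the dose given (going by the name of the read-out)), and all share one core, differing only in the group carried on the amide-type nitrogen. Compound 3 sits beyond the scatter above compound 2, as shown by a number 14.4 percentage points higher from compound 2 to compound 3 (beyond the scatter), while its gap to compound 1, a number 7.1 percentage points higher from compound 1 to compound 3 (within the scatter), lies within the scatter; compound 1 and compound 2 are likewise within the scatter of each other, a number 7.3 percentage points lower from compound 1 to compound 2 (within the scatter).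

Compound 4 `CC(=O)Oc1ccc(-c2ccc(F)cc2F)cc1C(=O)Nc1ccccc1Cl` is the next member. Relative to compound 3 the change is 2-chlorophenyl in place of 4-methylphenyl on an amide-type nitrogen. The measured steps that touch this position are the two leading into compound 3: a number 7.1 percentage points higher from compound 1 to compound 3 (within the scatter) and a number 14.4 percentage points higher from compound 2 to compound 3 (beyond the scatter). Both replace a saturated-chain group with an aromatic ring on the amide nitrogen; neither compares one aromatic ring with another, which is what the present change does. Among the measured compounds shown here, there is therefore no direct precedent for the size of this step, and a change within the scatter is the most reasonable expectation.

Compound 4 is thus expected to give 28%, with a range from 15% to 42%. The step this implies, a number 3 percentage points lower from compound 3 to compound 4 (within the scatter), is estimated to stay within the scatter.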

Compound 4, a percentage reported as inhibition, in the whole organism at one dose (the size of the read-out at that dose, not a potency): 11.7%
For compound 4 the middle estimate is 16.3 percentage points above the measured one, outside the stated range (below it).
By their numbers in this assay, from the lowest: compounds 4, 2, 1 and 3 (each within the scatter of the next, the first and the last beyond it).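

In this assay, replacing one aromatic ring on the amide-type nitrogen with another is far from a neutral exchange (a number 19.3 percentage points lower from compound 3 to compound 4 (beyond the scatter)), even though the leaving and entering groups have the same count of heavy atoms and the same kind of ring. An aromatic ring at this place therefore does not by itself bring the higher number of compound 3: the 2-chlorophenyl group falls short of the ethyl group of compound 1 (a number 12.2 percentage points lower from compound 1 to compound 4 (beyond the scatter)) and cannot be told apart from the benzyl group of compound 2 (a number 4.9 percentage points lower from compound 2 to compound 4 (within the scatter)). No measurement is available that explains this drop.

This change swaps a methyl group for a chlorine atom and also alters where the group sits on the ring, so the compounds shown cannot say which of the two matters for the step. The 4-chlorophenyl and 2-methylphenyl groups would separate these two changes, and an unsubstituted phenyl group on the amide-type nitrogen would show what the ring gives with neither present.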